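Swapping the anilino aryl group: compound 2 to compound 4

This account rests on a few compounds, and the source may have more. Where it says the series, first, only, none or still open, it means among the compounds named here.

Of the compounds shown here, three of one shared core have been measured in a functional assay on HCC827 cells (Homo sapiens) for inhibition, read by MTT assay, with a stated time of 48 h, tested at 10 uM; on this read-out higher numbers stand for more inhibition at the one concentration tested (going by the name of the read-out) and lower numbers for less inhibition. Compound 1 `CCc1ccc(Nc2cc(NC(=O)Nc3c(Cl)cccc3Cl)ncn2)cc1` gives 58%, compound 3 `COc1ccc(Nc2cc(NC(=O)Nc3c(Cl)cccc3Cl)ncn2)cc1C` gives 63.1%, and compound 2 `COc1cc(NC(=O)Nc2cc(Nc3ccc(C)c(F)c3)ncn2)cc(OC)c1` gives 72%, the highest of the three numbers, though compound 3 sits within the scatter of it and only compound 1 lies beyond the scatter below it. Compound 4 `CCc1ccc(Nc2cc(NC(=O)Nc3cc(OC)cc(OC)c3)ncn2)cc1` has not yet been measured in this assay . It differs from compound 2 in one place: 4-ethylphenyl in place of 3-fluoro-4-methylphenyl on a nitrogen on an aromatic ring. Among the measured compounds shown here, the one measured step at the same place, a number 5.1 percentage points higher from compound 1 to compound 3 (within the scatter), was within the scatter, so a change of the aryl group on that nitrogen has so far moved the number little. Compound 4 is therefore expected to stay close to compound 2, perhaps a little lower, with an expected step of a number 8 percentage points lower from compound 2 to compound 4 (within the scatter). Compound 4 is estimated at 64%, with a range from 48% to 78%.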

Compound 4, a percentage reported as inhibition, at one concentration (the size of the read-out at that concentration, not a potency): 66.2%
Compound 4: middle estimate off by 2.2 percentage points, on the low side; low and high end bracket the measured number.
By their numbers in this assay, from the lowest: compounds 1, 3, 4 and 2 (each within the scatter of the next, the first and the last beyond it).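

In this assay, among the compounds shown here, the change from 3-fluoro-4-methylphenyl to 4-ethylphenyl gives a number 5.8 percentage points lower from compound 2 to compound 4 (within the scatter), so a second step on the nitrogen stays within the scatter, this time with the partner group that compound 2 carries rather than the one shared by compound 1 and compound 3. The entering group has the same count of heavy atoms but no fluorine, and compound 4 shows that, with this partner, the fluorine is not needed to keep the number within the scatter of compound 2. No measurement available here explains why the number holds across this change.

For the compounds shown here, all the groups seen at this position so far are substituted phenyl rings without a charge. On these data alone, whether an amine or a carboxylic acid on that ring, or a chain longer than ethyl, would move the number beyond the scatter remains open.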